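Swapping a ring at the edge of a shared core

The source may report more compounds than this note shows. Statements on the series, on what has been measured and on what is new or still open speak of the compounds shown alone.

Of the compounds shown here, three built on one shared core have been measured in an assay on HEK293 cells for inhibition of acid ceramidase (Homo sapiens), read by fluorescence, with stated times of 10 min and 3 h; a lower number here means a stronger inhibitor, a higher number a weaker inhibitor. Compound 1 `CC(=O)N1CCC(c2ccc3c(c2)oc(=O)n3C(=O)NCCCCc2ccccc2)CC1` gives 64 nM, compound 2 `O=C(NCCCCc1ccccc1)n1c(=O)oc2cc(C3CCCCC3)ccc21` gives 89 nM, and compound 3 `O=C(NCCCCc1ccccc1)n1c(=O)oc2cnccc21` gives 3 nM. Compound 2 has the highest number of the three; compound 1 is its nearest neighbour, and the two lie within the usual scatter of each other, while compound 3 lies far below it, well beyond the scatter.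

Among the measured compounds shown here, the only measured step that touches the position in question is a 1.4-fold higher number from compound 1 to compound 2 (0.14 log units; within the scatter), where cyclohexyl replaced 1-acetylpiperidin-4-yl on an aromatic carbon; that step changed the number by less than the scatter.

Compound 4 `CCN1CCN(c2ccc3c(c2)oc(=O)n3C(=O)NCCCCc2ccccc2)CC1` carries 4-ethylpiperazin-1-yl in place of cyclohexyl on an aromatic carbon. Since the earlier exchange of a saturated six-membered ring at this position left the number essentially unchanged, a similarly small step is expected here, with no clear direction beyond the scatter. Compound 4 is therefore expected to give about 65 nM in this assay, with a likely range from 20 nM to 200 nM. The expected step from compound 2 to compound 4 is a 1.4-fold lower number from compound 2 to compound 4 (0.14 log units; within the scatter).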

Compound 4, half-maximal inhibitory concentration: 56 nM
Compound 4: middle estimate off by 1.2-fold (0.06 log units), on the high side; low and high end bracket the measured number.
By their numbers in this assay, from the lowest: compound 3; then compounds 4, 1 and 2 (each within the scatter of the next).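

In this assay, exchanging cyclohexyl for 4-ethylpiperazin-1-yl gives a 1.6-fold lower number from compound 2 to compound 4 (0.20 log units; within the scatter), and exchanging 1-acetylpiperidin-4-yl for the same group gives a 1.1-fold lower number from compound 1 to compound 4 (0.06 log units; within the scatter). This aromatic carbon has now carried three different six-membered non-aromatic rings without any printed step going beyond the scatter, and the newest ring has two hetero atoms and two hydrogen-bond acceptors where cyclohexyl has none, so these differences in ring make-up leave the number essentially where it was. No supporting measurement is available to explain why these exchanges make so little difference.

All three groups at this carbon are saturated six-membered rings, so the compounds shown leave open whether a flat phenyl ring, an open-chain amine or a carboxylic acid in the same place would also leave the number unchanged. Compound 3, at 3 nM, differs from the others in more than one place, so what sets its number apart cannot be read from these compounds.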